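The source may report more compounds than this note shows. Statements on the series, on what has been measured and on what is new or still open speak of the compounds shown alone.

Going by the values given here, compound 1 `C[C@@H]1CC(=O)N(c2cnc(NCc3c(F)ccc4c3CCO4)n3cnnc23)C1` is the first reference point. In an ADME assay on microsomes from liver (Homo sapiens) for metabolic stability, read by LC-MS, using NADPH, with stated times of 5 min and 30 min, tested at 1 uM (a higher number here means faster removal of the compound, a lower number slower removal), compound 1 gives < 3 mL.min-1.g-1, which is a limit of the assay rather than a number. Compound 2 `O=C(Nc1cnc(NCc2c(F)ccc3c2CCO3)n2cnnc12)c1ccccc1` in this assay gives 10 mL.min-1.g-1, the only true number among the two results shown. Among the compounds with values here, the single measured step, an at least 3.3-fold higher number from compound 1 to compound 2 (0.52 log units; beyond the scatter), is the one that bears on the next change. Compound 3 `O=C1CCCN1c1cnc(NCc2c(F)ccc3c2CCO3)n2cnnc12` differs from compound 2 by 2-oxopyrrolidin-1-yl in place of benzamido on an aromatic carbon, which runs the measured step roughly backwards, so in this assay a drop of similar size is expected, a 3.3-fold lower number from compound 2 to compound 3 (0.52 log units; beyond the scatter). Compound 3 is therefore estimated at 3 mL.min-1.g-1, with a range from 1.5 mL.min-1.g-1 to 7 mL.min-1.g-1.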

Compound 3, intrinsic clearance in microsomes: < 3 mL.min-1.g-1
Compound 3: a limit, no number; the forecaster's own chance of this, stated with the estimate: 50%; the middle value sits exactly at the limit.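

Putting 2-oxopyrrolidin-1-yl in place of benzamido on this aromatic carbon gives, in this assay, an at least 3.3-fold lower number from compound 2 to compound 3 (0.52 log units; beyond the scatter). Going by these compounds alone, until now, the low reading had been seen only with the 4-methyl-2-oxopyrrolidin-1-yl group of compound 1, and compound 3 shows that it also occurs without that methyl. Any effect of the methyl itself cannot be read, since compound 1 and compound 3 both give a limit and not a number: the limit of < 3 mL.min-1.g-1 in this assay, at which 2 of the 3 values shown sit.

Still open, as far as these compounds go, is whether a simple acetamido group, a 2-oxopiperidin-1-yl ring or a plain amine at this position would also reach that limit.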